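This account rests on a few compounds, and the source may have more. Where it says the series, first, only, none or still open, it means among the compounds named here.

Working notes on the series

Four compounds are considered. Compound 1 `O=CN1CCC[C@H]1COCCCCCC/C=C/c1ccc(-c2ccccc2)cc1` and compound 2 `O=CN1CCC[C@H]1COCCCCCCCCC/C=C/c1ccc(-c2ccccc2)cc1` are the two parent structures; they differ in their cores, and the difference between the two cores is not broken down here. Compound 3 `O=CN1CCC[C@H]1COCCCCCC/C=C/c1ccc(Oc2ccccc2)cc1` is built on the core of compound 1, and compound 4 `O=CN1CCC[C@H]1COCCCCCCCCC/C=C/c1ccc(Oc2ccccc2)cc1` is built on the core of compound 2 and has not been measured.

In a functional assay on BXPC-3 cells (Homo sapiens) for inhibition, read by XTT assay, with a stated time of 72 h (a lower number here means a stronger inhibitor, a higher number a weaker inhibitor), compound 1 gives 53300 nM. In this assay compound 2 gives 66700 nM, and compound 3 gives 46700 nM. All three values sit within the usual scatter of one another, so no order among them can be read.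

The change from compound 1 to compound 3 is phenoxy in place of phenyl on an aromatic carbon and made a step of a 1.1-fold lower number from compound 1 to compound 3 (0.06 log units; within the scatter). The same change is now applied on the other core: compound 4 differs from compound 2 by phenoxy in place of phenyl on an aromatic carbon, at the same place in the same words.

Because the earlier step was a 1.1-fold lower number from compound 1 to compound 3 (0.06 log units; within the scatter), the step from compound 2 to compound 4 is expected to be a 1.1-fold lower number from compound 2 to compound 4 (0.05 log units; within the scatter), again within the scatter. Compound 4 is therefore estimated at 60000 nM, with 30000 nM and 120000 nM as the expected bounds.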

Compound 4, half-maximal inhibitory concentration: 65000 nM
Estimate against measurement, compound 4: 1.1-fold (0.03 log units) below; the range from low to high includes it.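

On the core of compound 2, phenoxy in place of phenyl on an aromatic carbon makes a 1.0-fold lower number from compound 2 to compound 4 (0.01 log units; within the scatter) in this assay and the two cores agree on this change: the same change on two cores in this assay, a 1.1-fold lower number (0.06 log units; within the scatter) from compound 1 to compound 3 and a 1.0-fold lower number (0.01 log units; within the scatter) from compound 2 to compound 4, 1.1-fold (0.05 log units) apart, within the scatter of two such steps.

Within this pair of cores, the change therefore carries over only as a step too small to read on either core, so the agreement is between two steps that cannot be told from no step at all. It does not show that a step of readable size would carry from one core to the other, and it gives no sign of what the phenoxy or phenyl group contributes to the read-out.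

The compounds shown leave open whether another group on the same aromatic carbon, such as an amine or a carboxylic acid, would give a step beyond the scatter. They also leave open whether such a step would hold on the core of compound 1 and the core of compound 2 alike, or on a core with a longer chain.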